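This account rests on a few compounds, and the source may have more. Where it says the series, first, only, none or still open, it means among the compounds named here.

Among the compounds with values here, in a functional assay on SW-620 cells (Homo sapiens) (on this read-out lower numbers stand for stronger inhibition and higher numbers for weaker inhibition), no compound has yet given a number. Compound 1 (`COc1cc(NC(C)CCCNC(=O)NCCCO)c2ncccc2c1`) reads > 100000 nM, which is a limit. Compound 2 (`COc1cc(NC(C)CCCNC(=O)NC(CO)(CO)CO)c2ncccc2c1`) reads > 100000 nM, again a limit, so its standing is known only as that bound. Compound 3 (`COc1cc(N2C(=O)NCCCC2C)c2ncccc2c1`) reads > 100000 nM, also a limit.

Compound 4 (`COC(=O)NCCCC(C)Nc1cc(OC)cc2cccnc12`) has not been measured. It departs from compound 2 through (methoxy in place of (2-hydroxy-1,1-bis(hydroxymethyl)ethyl)amino on a carbonyl carbon), with methoxy in place of (2-hydroxy-1,1-bis(hydroxymethyl)ethyl)amino on a carbonyl carbon.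

Within the data shown here, the only measured step that touches this part of the structure is a step that the two limits leave unreadable from compound 1 to compound 2 and it offers no size to carry forward. Among the measured compounds shown here, all the evidence amounts to the limit of > 100000 nM in this assay, at which 3 of the 3 values shown sit, and it contains no step for this replacement. The data therefore support no expected direction in this assay and no particular size of change.

The expectation rests on compound 2 at > 100000 nM as its limit, and the same outcome is the likeliest reading for the new compound. The expected step is a number no higher from compound 2 to compound 4 (the limit leaves the size open) and it stays tentative. For compound 4 the estimated value is 100000 nM, with an expected range from 30000 nM to 200000 nM and a real chance that only a limit is reported.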

Compound 4, half-maximal inhibitory concentration: > 100000 nM
Compound 4: a limit, no number; the forecaster's own chance of this, stated with the estimate: 65%; the middle value lies on the limit itself.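

In this assay compound 4 gives > 100000 nM as a limit and not a number. The steps to compound 4 from compound 1 and from compound 2 therefore cannot be read. The compounds shown leave open whether any replacement on this carbonyl carbon changes inhibition at all, and they offer a single reading: the limit of > 100000 nM in this assay, at which 4 of the 4 values shown sit.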